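The compounds below may be only part of what the source reports. "The series", "measured", "known", "first", "only" and "open" are said of these compounds alone.

Compound 1 `Cc1c(C(=O)c2ccccc2)oc2ccc(NS(=O)(=O)c3ccc(F)cc3)cc12` carries a benzoyl group on its core. In a functional assay on PC-3 cells (Homo sapiens) for antiproliferative activity, read by MTT assay, with a stated time of 48 h (on this read-out lower numbers stand for stronger inhibition and higher numbers for weaker inhibition), compound 1 gives 38200 nM. Compound 2 `CCOC(=O)c1oc2ccc(NS(=O)(=O)c3ccc(F)cc3)cc2c1C` differs from it in a single place: ethoxy in place of phenyl on a carbonyl carbon In this assay compound 2 gives 15900 nM. The change brings a 2.4-fold lower number from compound 1 to compound 2 (0.38 log units; beyond the scatter), a step that is modest but lies beyond the usual scatter of repeated runs.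

Compound 3 `Cc1c(C(=O)c2ccccc2)oc2ccc(S(=O)(=O)Nc3ccc(F)cc3)cc12` is built from the same atoms as compound 1, joined differently; the difference between the two cores is not broken down here. In this assay compound 3 gives 22100 nM, a number that sits within the scatter of both compound 1 and compound 2, so no order among the three can be read from it.

Compound 4 `CCOC(=O)c1oc2ccc(S(=O)(=O)Nc3ccc(F)cc3)cc2c1C` has not yet been measured. It stands to compound 3 as compound 2 stands to compound 1: ethoxy in place of phenyl on a carbonyl carbon The place of the change is described in exactly the same words for both pairs, so this is the same change carried over to a different core.

Whether the step repeats on the new core rests on a single earlier example. If it does, compound 4 is expected to show a 2.3-fold lower number from compound 3 to compound 4 (0.37 log units; beyond the scatter), an expectation resting on a 2.4-fold lower number from compound 1 to compound 2 (0.38 log units; beyond the scatter). For the measured compounds named here, compound 4 is therefore estimated at 9500 nM, with a likely span from 4000 nM to 22000 nM, the width reflecting that only one prior instance of this change is available.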

Compound 4, half-maximal inhibitory concentration: 8560 nM
The estimate for compound 4 lay 1.1-fold (0.05 log units) above the measured number, and the stated range covers the measured number.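

In this assay, replacing phenyl with ethoxy on the carbonyl carbon again gives a lower number, which means stronger inhibition on this read-out, with a 2.6-fold lower number from compound 3 to compound 4 (0.41 log units; beyond the scatter). Set beside the earlier case, the step comes out at nearly the same size on the two cores: the same change on two cores in this assay, a 2.4-fold lower number (0.38 log units; beyond the scatter) from compound 1 to compound 2 and a 2.6-fold lower number (0.41 log units; beyond the scatter) from compound 3 to compound 4, 1.1-fold (0.03 log units) apart, within the scatter of two such steps. So, for these two cores, which are built from the same atoms joined differently, the change carries over in both direction and size, but two matched pairs cannot establish a rule for the whole series or say how the change would behave on any other core.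

The compounds shown leave open whether the step belongs to ethoxy in particular or would also appear with other groups on the same carbonyl carbon, such as methoxy, a longer chain like butoxy, an amine giving an amide, or the free carboxylic acid. They also leave open whether the same step would appear in cells other than the one line tested here, since all four compounds are compared in this single assay.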